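Replacing the Side Chain of Compound 2

This account rests on a few compounds, and the source may have more. Where it says the series, first, only, none or still open, it means among the compounds named here.

In an ADME assay on CEM-SS cells (Homo sapiens) for cytotoxicity, read by XTT assay, with a stated time of 6 days (a higher number here means that more compound is tolerated, a lower number that less compound is tolerated), compound 1 `CCCC(=O)OCSc1ccccc1C(=O)NCCCCCCC(N)=O` gives 10.4 uM. For the measured compounds named here, compound 2 `CCCC(=O)OCSc1ccccc1C(=O)NCCCNC(C)=O` gives 21.1 uM, the higher of the two numbers so far. Compound 3 `CCCC(=O)OCSc1ccccc1C(=O)N(C)CC(=O)NC` has not yet been measured. It differs from compound 2 as follows: methyl((methylcarbamoyl)methyl)amino in place of (3-acetamidopropyl)amino on a carbonyl carbon. In words, methyl((methylcarbamoyl)methyl)amino stands in place of (3-acetamidopropyl)amino on a carbonyl carbon.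

Going by the values given here, only one measured step bears on this change, and only loosely. That step, a 2.0-fold higher number from compound 1 to compound 2 (0.31 log units; beyond the scatter), puts acetamido in place of 3-carbamoylpropyl on a saturated chain carbon, and it is modest. Among the compounds with values here, it is a different exchange, so it offers no firm direction for the new one and suggests only that steps here may be small. The expected step is therefore none beyond the scatter, estimated as a 1.0-fold higher number from compound 2 to compound 3 (0.02 log units; within the scatter). Compound 3 is expected at 22 uM, with an estimated range of 9 uM to 55 uM.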

Compound 3, half-maximal toxic concentration: 62.5 uM
The estimate for compound 3 lay 2.8-fold (0.45 log units) below the measured number; the whole stated range lies below it.
By their numbers in this assay, from the lowest: compound 1; then compound 2; then compound 3.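

In this assay, methyl((methylcarbamoyl)methyl)amino in place of (3-acetamidopropyl)amino on a carbonyl carbon gives a 3.0-fold higher number from compound 2 to compound 3 (0.47 log units; beyond the scatter) and so shows that the whole side chain at this place can be exchanged with a change beyond the scatter, here towards more compound tolerated. The entering group has 7 heavy atoms and 1 hydrogen-bond donor where the leaving group has 8 and 2, and this single step cannot separate those differences from the change in the shape of the chain. Nothing measured here explains the higher number.

The compounds shown leave open whether the same group without the methyl on its amino nitrogen would give a similar number. They also leave open how a carboxylic acid, an amine or a longer chain would behave at this place.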